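The source may report more compounds than this note shows. Statements on the series, on what has been measured and on what is new or still open speak of the compounds shown alone.

Compound 1 `COc1ccc2c(=O)c(/C=C/C(=O)Nc3cccc(Cl)c3)coc2c1`: 1100000 nM
Compound 2 `COc1ccc2c(=O)c(/C=C/C(=O)Nc3ccccc3Cl)coc2c1`: 1010000 nM

In an ADME assay on HepG2 2.2.15 cells (Homo sapiens) for cytotoxicity, read by MTT assay, with stated times of 48 h and 9 days (on this read-out lower numbers stand for higher toxicity in this test and higher numbers for lower toxicity in this test), compound 1 gives 1100000 nM, and compound 2 gives 1010000 nM; the two numbers lie within the scatter of each other, so neither stands apart. Among the measured compounds shown here, the one measured step, a 1.1-fold lower number from compound 1 to compound 2 (0.04 log units; within the scatter), is the only one that bears on the change to compound 3 `COc1ccc2c(=O)c(/C=C/C(=O)NCc3cccc(F)c3)coc2c1`, which carries 3-fluorobenzyl in place of 3-chlorophenyl on an amide-type nitrogen. That step was within the scatter, so no shift beyond the scatter is expected for compound 3, with the step of a 1.1-fold lower number from compound 1 to compound 3 (0.04 log units; within the scatter) as its expected size. Compound 3 is therefore estimated at 1000000 nM in this assay, between 500000 nM and 2000000 nM.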

Compound 3, half-maximal cytotoxic concentration: 475000 nM
Compound 3: middle estimate off by 2.1-fold (0.32 log units), on the high side; measured number below the stated range.
By their numbers in this assay, from the lowest: compound 3; then compounds 2 and 1 (each within the scatter of the next).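

In this assay, the exchange of 3-chlorophenyl for 2-chlorophenyl had produced no shift beyond the scatter, but 3-fluorobenzyl on the amide-type nitrogen does, with a 2.3-fold lower number from compound 1 to compound 3 (0.36 log units; beyond the scatter) and a 2.1-fold lower number from compound 2 to compound 3 (0.33 log units; beyond the scatter). This position therefore responds to at least one change, although both steps are modest and compound 3 remains the lowest of the three. No evidence accounts for the shift.

As far as these compounds go, whether it follows the fluorine or the benzyl form of the group stays open. So does what a 3-chlorobenzyl group, a longer chain or an amine would give at this nitrogen.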